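The source may report more compounds than this note shows. Statements on the series, on what has been measured and on what is new or still open speak of the compounds shown alone.

Measured in a functional assay on SW480 cells (Homo sapiens) for antiproliferative activity, read by MTT assay, with a stated time of 48 h; a lower number here means a stronger inhibitor, a higher number a weaker inhibitor:
Compound 1 `CC(CCO)n1cnc2c(Cl)ncnc21`: > 50000 nM (a limit of the assay, not a number)
Compound 2 `CCCCCCCCC[C@H](CCOS(C)(=O)=O)n1cnc2c(Cl)ncnc21`: 9720 nM
Compound 3 `CCCCCCCCCC(CCOS(C)(=O)=O)n1cnc2c(Cl)ncnc21`: 5390 nM

Within the data shown here, compound 3 and compound 2 hold the only two actual numbers in this set, and they lie within the scatter of each other. Compound 4 `CCCCCCCCCC(CCCl)n1cnc2c(Cl)ncnc21` alters compound 3 in one place, with chloro in place of (methylsulfonyl)oxy on a saturated chain carbon, three bonds along the chain from an aromatic nitrogen. Among the measured compounds shown here, the single measured step, a 1.8-fold lower number from compound 2 to compound 3 (0.26 log units; within the scatter), concerns only the fact that one of compounds 2 and 3 is drawn with a defined configuration and the other without, at the place where they differ and leaves this group untouched, so it gives no size for the swap. For the measured compounds named here, compound 1 rests at a limit and supplies no step either. The best guide is therefore compound 3 itself at 5390 nM, and no clear move in either direction is expected in this assay. The expected step is a 1.1-fold higher number from compound 3 to compound 4 (0.05 log units; within the scatter) and the uncertainty around it is wide. For compound 4 the estimated value is 6000 nM, with an expected range from 2000 nM to 20000 nM.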

Compound 4, half-maximal inhibitory concentration: 7180 nM
For compound 4 the middle estimate is 1.2-fold (0.08 log units) below the measured one, within the range that was stated.
By their numbers in this assay, from the lowest: compounds 3, 4 and 2 (each within the scatter of the next). At a limit, above all of these: compound 1.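

In this assay, putting chloro in place of (methylsulfonyl)oxy gives a 1.3-fold higher number from compound 3 to compound 4 (0.12 log units; within the scatter). Among these compounds, this is the first measured change at this group on the saturated chain carbon, three bonds along the chain from an aromatic nitrogen, and it shows that a group of 5 heavy atoms with 3 hydrogen-bond acceptors can give way to a single chlorine atom with no change that stands out from the scatter. Nothing measured here offers a reason for this result.

On these data alone, what an amine, an azide or a bromo group would give at the same place remains open. Also open, as far as these compounds go, is whether chloro and (methylsulfonyl)oxy would stay this close on a chain of another length, such as a hexyl chain.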